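Three Amides at the Assay Limit and a Fourth Expected There

The source may report more compounds than this note shows. Statements on the series, on what has been measured and on what is new or still open speak of the compounds shown alone.

Compound 1, `O=C(CN1CCCCC1)Nc1ccc2ncnc(Nc3cccc(C(F)(F)F)c3)c2c1`: > 100000 nM
Compound 2, `CN1CCN(CC(=O)Nc2ccc3ncnc(Nc4cccc(C(F)(F)F)c4)c3c2)CC1`: > 100000 nM
Compound 3, `O=C(CN1CCCCC1)Nc1ccc2ncnc(Nc3ccc(Br)cc3)c2c1`: > 100000 nM

In a functional assay on HepG2 cells (Homo sapiens) for antiproliferative activity, read by MTT assay, with a stated time of 48 h (a lower number here means a stronger inhibitor, a higher number a weaker inhibitor), compound 1 gives only a limit. Compound 2 is reported at a limit as well. Compound 3 likewise stands at a limit, not at a number. The step that the two limits leave unreadable from compound 1 to compound 2 goes with the change (4-methylpiperazin-1-yl in place of piperidin-1-yl on a saturated chain carbon bound to a carbonyl carbon). The step that the two limits leave unreadable from compound 1 to compound 3 goes with 4-bromophenyl in place of 3-(trifluoromethyl)phenyl on a nitrogen on an aromatic ring, which is how the core of compound 3 differs from the core of compound 1. All three values sit at the limit of > 100000 nM in this assay, at which 3 of the 3 values shown sit, so neither step can be sized.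

Compound 4, `CN1CCN(CC(=O)Nc2ccc3ncnc(Nc4ccc(Br)cc4)c3c2)CC1`, is not yet measured in this assay. From compound 3 it differs by 4-methylpiperazin-1-yl in place of piperidin-1-yl on a saturated chain carbon bound to a carbonyl carbon, the same change as from compound 1 to compound 2, made at the same place. That earlier step could not be read because compound 1 and compound 2 both sit at the limit of > 100000 nM in this assay, at which 3 of the 3 values shown sit, and compound 3 sits there too. Compound 4 is therefore expected to remain at the limit, with an expected step that the limit leaves unreadable from compound 3 to compound 4. The estimate for compound 4 is 150000 nM, between 50000 nM and 500000 nM.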

Compound 4, half-maximal inhibitory concentration: > 100000 nM
Compound 4: a limit, no number (the forecaster's own chance of this, stated with the estimate: 85%); the middle value lies beyond the limit too.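

In this assay compound 4 gives > 100000 nM, a limit and not a number. The steps from compound 3 and from compound 2 to compound 4 therefore cannot be read, since all the values share one limit: the limit of > 100000 nM in this assay, at which 4 of the 4 values shown sit. The compounds shown leave open whether either change affects antiproliferative activity, and how far each compound lies beyond that limit.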